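The compounds below may be only part of what the source reports. "The series", "measured", "known", "first", "only" and "open" are said of these compounds alone.

Working notes on the series. Three compounds share a sulfonamide-linked urea built on the same core. Compound 3 `Cc1ccc(-c2ccsc2S(=O)(=O)NCCNC(=O)Nc2cc(Cl)cc(Cl)c2)c(Oc2ccc(O)c(O)c2)c1` carries a dichlorophenyl urea and in a functional assay on HeLa cells (Homo sapiens) for inhibition, read by CCK-8 assay, with a stated time of 48 h (a lower number here means a stronger inhibitor, a higher number a weaker inhibitor), compound 3 gives 6500 nM. Compound 2 `Cc1ccc(-c2ccsc2S(=O)(=O)NCCNC(=O)Nc2cc(C(F)(F)F)cc(C(F)(F)F)c2)c(Oc2ccc(O)c(O)c2)c1` carries a bis(trifluoromethyl)phenyl urea in its place; in this assay compound 2 gives 9700 nM, which sits within the scatter of compound 3, so no order between the two is read. How the cores of compound 2 and compound 3 differ is not broken down here. Compound 1 `O=C(NCCNS(=O)(=O)c1sccc1-c1ccccc1Oc1ccc(O)c(O)c1)Nc1cc(Cl)cc(Cl)c1` is the analogue of compound 3 with hydrogen in place of methyl on an aromatic carbon. In this assay compound 1 gives only a limit, > 50000 nM. The step of an at least 7.6-fold higher number from compound 3 to compound 1 (0.88 log units; beyond the scatter) is therefore a floor, resting on (the limit of > 50000 nM in this assay, at which 1 of the 3 values shown sits). Compound 4 `O=C(NCCNS(=O)(=O)c1sccc1-c1ccccc1Oc1ccc(O)c(O)c1)Nc1cc(C(F)(F)F)cc(C(F)(F)F)c1`, not yet measured, repeats the same change on compound 2: hydrogen in place of methyl on an aromatic carbon. Because the measured step of an at least 7.6-fold higher number from compound 3 to compound 1 (0.88 log units; beyond the scatter) is at least modest, the same step is expected for compound 4, a 7.2-fold higher number from compound 2 to compound 4 (0.86 log units; beyond the scatter), carrying it past the limit of this assay. For compound 4 the expected value in this assay is 70000 nM, between 25000 nM and 200000 nM.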

Compound 4, half-maximal inhibitory concentration: > 50000 nM
Compound 4: only a limit was reported (the forecaster's own chance of this, stated with the estimate: 70%); the middle value is on the limit's open side.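

In this assay, compound 4 gives only a limit, > 50000 nM. The step of an at least 5.1-fold higher number from compound 2 to compound 4 (0.71 log units; beyond the scatter) is therefore a floor, and it shows that hydrogen in place of methyl on this aromatic carbon gives a higher number with the dichlorophenyl urea and with the bis(trifluoromethyl)phenyl urea, with neither pair going against this: the same change on two cores in this assay, an at least 7.6-fold higher number (0.88 log units; beyond the scatter) from compound 3 to compound 1 and an at least 5.1-fold higher number (0.71 log units; beyond the scatter) from compound 2 to compound 4; the limit leaves it open whether they differ. What this does not show is the true size of the step on either core, or whether the urea group alters that size, since both steps end at the same limit: the limit of > 50000 nM in this assay, at which 2 of the 4 values shown sit.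

Going by these compounds, it remains open whether a group other than methyl on the same aromatic carbon, such as an ethyl, a methoxy or a chlorine, would give a number near those of compound 2 and compound 3. On these data alone, it also remains open whether the step would carry over to an unsubstituted phenyl urea, and only a compound that reads inside the range of the assay could put a size on it.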